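The source may hold more compounds than are shown below. What is called first, only, known or untested is meant among the compounds shown, and "the series" means these compounds.

In a functional assay on HepG2 cells (Homo sapiens) for cytotoxicity, read by MTT assay, with a stated time of 48 h (on this read-out higher numbers stand for weaker inhibition and lower numbers for stronger inhibition), the two measured compounds set a low bar. Compound 1, with the structure `O=C(c1ccccc1)N1N=C(c2cc3ccccc3oc2=O)CC1c1ccccc1`, gives 36600 nM. Compound 2, with the structure `O=C(CN1CCC(O)CC1)N1N=C(c2cc3ccccc3oc2=O)CC1c1ccccc1`, belongs to the same series, and in this assay compound 2 is recorded as "not active" (no number reported), so it has no number to stand on: it sits among the compounds for which no half-maximal concentration could be reported, and it cannot be placed on the scale at all.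

Compound 3, with the structure `NC(=O)C1CCN(CC(=O)N2N=C(c3cc4ccccc4oc3=O)CC2c2ccccc2)CC1`, is the next step from compound 2. The change is carbamoyl in place of hydroxy on a saturated ring carbon of the six-membered non-aromatic ring that carries one nitrogen. Within the data shown here, no step between measured compounds shows what such a swap does here, so the direction of the step in this assay can only be guessed; the likeliest outcome is no change beyond the scatter, with compound 3 remaining weak. Compound 3 is therefore expected to give about 60000 nM, within a range from 20000 nM to 200000 nM, and there is a fair chance that this assay again reports no number for it.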

Compound 3, half-maximal inhibitory concentration: 19300 nM
The estimate for compound 3 lay 3.1-fold (0.49 log units) above the measured number, outside the stated range (below it).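

In this assay the hydroxy of compound 2 leaves no number, while with carbamoyl on the same saturated ring carbon compound 3 gives 19300 nM and so stands on the scale, which shows that this ring position can carry a group that yields a readable value, though the swap itself has no size when one of its two ends has no number. Putting (4-carbamoylpiperidin-1-yl)methyl in place of phenyl on the carbonyl carbon gives a 1.9-fold lower number from compound 1 to compound 3 (0.28 log units; within the scatter) and thus leaves the two groups indistinguishable in this assay, so a large change at that carbonyl carbon is compatible with a value that stays in the same weak range. Nothing measured here accounts for the gap between hydroxy and carbamoyl on this ring.

The compounds shown leave open what an amine or a carboxylic acid would do on the same saturated ring carbon, and whether such a group would give a number at all. They also leave open what a longer chain would do in place of the methyl that links the piperidine nitrogen to the carbonyl carbon, and whether any such change moves the value beyond the usual scatter.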